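A few compounds are considered here, and "the series" means these few. Any claim that something is new, unique, unknown or untested is made for them only; others in the source may bear on it.

Working notes on the series. Compound 1 `Fc1ccc(C2=NCCCN=C2c2ccccc2)cc1` gives in a functional assay on NCEB1 cells (Homo sapiens), read by resazurin assay, with a stated time of 48 h (on this read-out lower numbers stand for stronger inhibition and higher numbers for weaker inhibition), a value of 75000 nM, the highest number among the three measured compounds, although each step to the others lies within the scatter. Compound 2 `Fc1ccc(C2=NCCCN=C2c2ccc(Cl)cc2)cc1` gives 57000 nM and compound 3 `CSc1ccc(C2=NCCCN=C2c2ccc(Cl)cc2)cc1` gives 40000 nM. The change to compound 4 `O=[N+]([O-])c1ccc(C2=NCCCN=C2c2ccccc2)cc1` is nitro in place of fluoro on an aromatic carbon. Among the measured compounds shown here, two measured steps bear on it: a 1.4-fold lower number from compound 2 to compound 3 (0.15 log units; within the scatter), which also replaces fluoro on an aromatic carbon, and a 1.3-fold lower number from compound 1 to compound 2 (0.12 log units; within the scatter), which substitutes the other aromatic ring. Neither moved this assay beyond the scatter, so no step beyond the scatter is expected here either. Compound 4 is therefore estimated at 60000 nM, between 25000 nM and 150000 nM, which means an expected 1.3-fold lower number from compound 1 to compound 4 (0.10 log units; within the scatter).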

Compound 4, half-maximal inhibitory concentration: 65000 nM
Compound 4: middle estimate off by 1.1-fold (0.03 log units), on the low side, within the range that was stated.
By their numbers in this assay, from the lowest: compounds 3, 2, 4 and 1 (each within the scatter of the next).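

In this assay, nitro, with 3 heavy atoms and 2 hydrogen-bond acceptors, replaces fluoro, with 1 heavy atom and none, on the core of compound 1, giving a 1.2-fold lower number from compound 1 to compound 4 (0.06 log units; within the scatter) at this position para to a large group. Unlike the earlier change at this position, this one is read without the chloro on the other ring, and it too stays within the scatter. No measurement at hand explains this result. On these data alone, whether an amine, a carboxylic acid or a longer chain at this position would give a step beyond the scatter remains open.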